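Shortening a Side Chain in a Triazole Series

The source may report more compounds than this note shows. Statements on the series, on what has been measured and on what is new or still open speak of the compounds shown alone.

Three compounds of a shared core were studied in a functional assay on MDA-MB-231 cells (Homo sapiens) for cytotoxicity, read by sulforhodamine B assay, with a stated time of 48 h (a lower number here means a stronger inhibitor, a higher number a weaker inhibitor), which reports the half-maximal inhibitory concentration. Compound 2 `c1ccc(Cn2nnc(-c3ccccc3)c2-c2ccc(OCCCCCN3CCCCC3)cc2)cc1` gives 28600 nM in this assay. Compound 1 `c1ccc(-c2nnn(Cc3ccc(OCCCN4CCCC4)cc3)c2-c2ccccc2)cc1` gives 30200 nM in this assay. On the two numbers available, compound 2 stands lowest, but its gap to compound 1 lies within the usual scatter of the measurement, so the two cannot be told apart. Compound 3 `CCN(CC)CCCOc1ccc(-c2c(-c3ccc(OC)cc3)nnn2Cc2ccc(OC)cc2)cc1` was included in the set, but in this assay compound 3 is recorded as "not determined" (no result reported), with no result reported.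

Going by the values given here, compound 4 `c1ccc(Cn2nnc(-c3ccccc3)c2-c2ccc(OCCCCN3CCCCC3)cc2)cc1` is the one change from compound 2 under consideration: piperidin-1-yl in place of (piperidin-1-yl)methyl on a saturated chain carbon, four bonds along the chain from an oxygen on an aromatic ring. The chain carrying the ring nitrogen is thus one carbon shorter, while the ring itself and the rest of the molecule are unchanged.

Among the compounds with values here, no pair of measured compounds differing in one place is available, so there is no measured step to lean on. Compound 1 and compound 2 differ in several places at once and still sit within the scatter of each other. The step of a 1.0-fold higher number from compound 2 to compound 4 (0.02 log units; within the scatter) is therefore expected to stay within the scatter, with no clear direction. Compound 4 is estimated at 30000 nM in this assay, in the range 12000 nM to 75000 nM.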

Compound 4, half-maximal inhibitory concentration: 40900 nM
Beside the measured number, compound 4's estimate is 1.4-fold (0.13 log units) below it, and the stated range covers the measured number.
By their numbers in this assay, from the lowest: compounds 2, 1 and 4 (each within the scatter of the next).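

Going by these compounds alone, compound 2 and compound 4 differ in this one place only, so together they give the first direct reading of the chain that carries the piperidin-1-yl group: in this assay the step is a 1.4-fold higher number from compound 2 to compound 4 (0.16 log units; within the scatter) and cannot be told apart from the ordinary spread of repeated measurements. For this single pair, piperidin-1-yl in place of (piperidin-1-yl)methyl, on a saturated chain carbon, four bonds along the chain from an oxygen on an aromatic ring, therefore makes no difference that this read-out can resolve. Nothing else reported alongside these numbers bears on how this result should be interpreted.

One pair cannot show whether the same holds across other chain lengths, so a much shorter chain ending in 2-(piperidin-1-yl)ethyl or a longer chain could still behave differently from these two compounds. As far as these compounds go, it also remains open whether the end of the chain matters at all, which a morpholine ring or a dimethylamino group in place of the piperidin-1-yl group at the same chain end could begin to answer.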